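The source may report more compounds than this note shows. Statements on the series, on what has been measured and on what is new or still open speak of the compounds shown alone.

Measured so far:
Compound 1 `Cc1cc(C)c(Oc2cc(Nc3ccc(C#N)cc3)ncc2C(=O)NCc2cn(Cc3ccccc3F)nn2)c(C)c1`. In an ADME assay on MT4 cells (Homo sapiens) for cytotoxicity, read by MTT assay, with a stated time of 5 days (a lower number here means that less compound is tolerated, a higher number that more compound is tolerated), compound 1 gives > 222000 nM, which is a limit of the assay and not a number.
Compound 2 `Cc1cc(C)c(Oc2cc(Nc3ccc(C#N)cc3)ncc2C(=O)NCc2cn(Cc3ccccc3Cl)nn2)c(C)c1`. In this assay compound 2 gives >= 188000 nM, again a limit of the assay rather than a number.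
Compound 3 `CC(=O)Cn1cc(CNC(=O)c2cnc(Nc3ccc(C#N)cc3)cc2Oc2c(C)cc(C)cc2C)nn1`. In this assay compound 3 gives 19400 nM.

Compound 3 therefore stands as the only one of the three with a readable number; compound 1 sits at the limit of > 222000 nM in this assay, at which 1 of the 3 values shown sits. Compound 2 sits at the limit of >= 188000 nM in this assay, at which 1 of the 3 values shown sits. The unmeasured compound 4 `Cc1cc(C)c(Oc2cc(Nc3ccc(C#N)cc3)ncc2C(=O)NCc2cn(Cc3ccc(F)cc3)nn2)c(C)c1` differs from compound 3 by 4-fluorophenyl in place of acetyl on a saturated chain carbon bound to an aromatic nitrogen. Among the compounds with values here, two measured steps bear on this change, each running in the opposite direction: an at least 11-fold lower number from compound 1 to compound 3 (1.05 log units; beyond the scatter), and an at least 9.6-fold lower number from compound 2 to compound 3 (0.98 log units; beyond the scatter). Within the data shown here, the step that the two limits leave unreadable from compound 1 to compound 2 shows only that both halogenated benzyl compounds reach the limit. Compound 4 carries a 4-fluorophenyl where compound 1 carries a 2-fluorophenyl and compound 2 a 2-chlorophenyl, so the change from acetyl back to an aryl group is expected to undo the drop seen in the measured steps and to give a higher number in this assay, quite possibly a limit once more. Compound 4 is accordingly expected to give about 200000 nM, within a range from 60000 nM to 300000 nM. That estimate means an expected step of a 10-fold higher number from compound 3 to compound 4 (1.01 log units; beyond the scatter).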

Compound 4, half-maximal cytotoxic concentration: >= 153000 nM
Compound 4: no number, only a limit; the forecaster's own chance of this, stated with the estimate: 65%; the middle value lies beyond the limit too.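

The change from 2-oxopropyl to 4-fluorobenzyl gives, in this assay, an at least 7.8-fold higher number from compound 3 to compound 4 (0.89 log units; beyond the scatter), so a third halogenated aryl group on this saturated chain carbon bound to an aromatic nitrogen also stands clear of the acetyl compound. Compound 4 stands at a limit of the assay and not at a number: the limit of >= 153000 nM in this assay, at which 1 of the 4 values shown sits. Compound 1, compound 2 and compound 4 all give limits, and the steps among them cannot be read, so 4-fluorophenyl, 2-fluorophenyl and 2-chlorophenyl cannot be ordered against one another, and the fluorine of 4-fluorophenyl shows no readable difference from the other two groups.

Compound 3 is the only one shown with acetyl at this place, so the compounds leave open whether its lower number goes with the carbonyl or simply with the absence of an aryl ring. An unsubstituted phenyl, a longer chain ending in a carbonyl, an amine or a carboxylic acid at the same place would be needed to tell these readings apart, and any of them might give a readable number rather than a limit.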